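Hydroxy to methoxy on the pendant phenyl of compound 1

A few compounds are considered here, and "the series" means these few. Any claim that something is new, unique, unknown or untested is made for them only; others in the source may bear on it.

Compound 1 `CCc1ccc(-c2nc3c(c(C)nn3-c3ccccc3)c(-c3ccccc3O)c2C#N)cc1` gives 3100 nM in a physicochemical assay for solubility, read by spectrophotometry, in phosphate buffer, with a stated time of 18 h, at pH 7.4 (a lower number here means a less soluble compound, a higher number a more soluble compound), and stands lowest of the three numbers. Compound 2 `CCc1ccc(-c2nc3c(c(C)nn3-c3ccccc3)c(-c3ccccc3I)c2C#N)cc1` gives 8500 nM, compound 3 `CCc1ccc(-c2nc3c(c(C)nn3-c3ccccc3)c(-c3ccccc3C(F)(F)F)c2C#N)cc1` gives 11000 nM; between them a 1.3-fold higher number from compound 2 to compound 3 (0.11 log units; within the scatter). The move to compound 4 `CCc1ccc(-c2nc3c(c(C)nn3-c3ccccc3)c(-c3ccccc3OC)c2C#N)cc1` is methyl in place of hydrogen on an oxygen on an aromatic ring, which, cut one bond further out, reads hydroxy to methoxy. Two measured steps also remove the hydroxy: a 2.7-fold higher number from compound 1 to compound 2 (0.44 log units; beyond the scatter) and a 3.5-fold higher number from compound 1 to compound 3 (0.55 log units; beyond the scatter), both modest rises. A rise of similar or somewhat smaller size is therefore expected here. The step from compound 1 to compound 4 is expected at a 1.9-fold higher number from compound 1 to compound 4 (0.29 log units; within the scatter). Compound 4 is estimated at 6000 nM, with a range from 3000 nM to 12000 nM.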

Compound 4, solubility: 7800 nM
Beside the measured number, compound 4's estimate is 1.3-fold (0.11 log units) below it, and the stated range covers the measured number.
By their numbers in this assay, from the lowest: compound 1; then compounds 4, 2 and 3 (each within the scatter of the next).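

In this assay, methyl on the oxygen alone gives a 2.5-fold higher number from compound 1 to compound 4 (0.40 log units; beyond the scatter), so the hydroxy need not be replaced outright for a modest step at this place. Methoxy is not separated from trifluoromethyl (a 1.4-fold lower number from compound 3 to compound 4 (0.15 log units; within the scatter)) or from iodo (a 1.1-fold lower number from compound 2 to compound 4 (0.04 log units; within the scatter)), which leaves three different groups within the scatter of one another and only compound 1 apart from them. No measured property of these compounds accounts for this.

Still open, from the compounds shown here alone, is how an amine or a carboxylic acid would read at this place. Also open, going by these compounds, is whether a longer chain on the oxygen, such as ethoxy, would hold the number.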